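Swapping the Urea-Side Group in a Pyrazole Series

The compounds below may be only part of what the source reports. "The series", "measured", "known", "first", "only" and "open" are said of these compounds alone.

Measured compounds:
- compound 1 `O=C(Nc1cccc(-n2cc(-c3ccncc3)c(-c3cc(O)cc(Cl)c3)n2)c1)Nc1ccc(Cl)c(C(F)(F)F)c1` gives 102%
- compound 2 `COc1cc(Cl)cc(-c2nn(-c3cccc(NC(=O)Nc4ccc(Cl)c(C(F)(F)F)c4)c3)cc2-c2ccncc2)c1` gives 93%
- compound 3 `COc1cc(Cl)cc(-c2nn(-c3cccc(NC(=O)Nc4cc(C(F)(F)F)cc(C(F)(F)F)c4)c3)cc2-c2ccncc2)c1` gives 92%

All three numbers come from a functional assay on UACC-62 cells (Homo sapiens) for inhibition, read by sulforhodamine B assay, with a stated time of 48 h, tested at 0.1 uM; a lower number here means a stronger effect, a higher number a weaker effect of the compound at the concentration tested. On these numbers compound 2 stands second of three, with compound 3 within the scatter of it and compound 1 within the scatter as well, so none of the three can be called stronger or weaker than another. Within the data shown here, the one single-point step that has been measured, a number 9 percentage points lower from compound 1 to compound 2 (within the scatter), is itself within the scatter.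

Compound 4 `COc1cc(Cl)cc(-c2nn(-c3cccc(NC(=O)c4cccc(C(F)(F)F)c4)c3)cc2-c2ccncc2)c1` has not yet been measured. It differs from compound 2 in one place: 3-(trifluoromethyl)phenyl in place of (4-chloro-3-(trifluoromethyl)phenyl)amino on a carbonyl carbon. Among the measured compounds shown here, no measured step touches this part of the structure, so nothing in the data speaks for a change in either direction; the only guide is that every compound measured so far sits near the no-effect level in this assay. The expectation for compound 4 is therefore a step of about a number 4 percentage points higher from compound 2 to compound 4 (within the scatter), that is, none beyond the scatter. Compound 4 is expected to give roughly 97%, within a range from 85% to 108%.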

Compound 4, a percentage reported as activity, at one concentration (the size of the read-out at that concentration, not a potency): 94%
Estimate against measurement, compound 4: 3 percentage points above, within the range that was stated.
By their numbers in this assay, from the lowest: compounds 3, 2, 4 and 1 (each within the scatter of the next).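

Among these compounds, this is the first measured change on the urea side of the molecule: on the carbonyl carbon, 3-(trifluoromethyl)phenyl takes the place of (4-chloro-3-(trifluoromethyl)phenyl)amino, so the urea becomes an amide and the amide-type hydrogen of the leaving group is gone. In this assay this exchange gives a number 1 percentage points higher from compound 2 to compound 4 (within the scatter), so compound 4 cannot be told apart from compound 2 at this single concentration, and the read-out gives no sign that this hydrogen or the leaving group's chlorine matters here. Nothing in the available data offers an explanation for this result.

The compounds shown leave open what a morpholine or a plain butyl chain on this carbonyl carbon would give. They also leave open whether compound 2 and compound 4 would still match at a higher concentration, where a clearer effect might be seen.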